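The source may hold more compounds than are shown below. What is called first, only, known or untested is meant among the compounds shown, and "the series" means these compounds.

Compound 1 `CCCCc1cn(-c2ccc(NC(=O)Nc3cc(O)ccc3C)cc2)nn1` gives the lower of the two numbers in an assay on isolated protein for inhibition of ATP-dependent RNA helicase DDX3X (Homo sapiens), read by FRET, with stated times of 30 s and 40 min (a lower number here means a stronger inhibitor, a higher number a weaker inhibitor), at 490 nM. Compound 2 `Cc1ccccc1NC(=O)Nc1ccc(-n2cc(CCCN(C)C)nn2)cc1` gives 2900 nM in this assay, a gap beyond the usual scatter. Compound 3 `CCCCc1cn(-c2ccc(NC(=O)Nc3cc(OC4CCOC4)ccc3C)cc2)nn1` differs from compound 1 in one place: oxolan-3-yl in place of hydrogen on an oxygen on an aromatic ring. Within the data shown here, no measured pair shows this change, so the size of its effect in this assay is not known from the data; a modest step toward a higher number, at about the edge of the scatter, is expected. On that basis compound 3 is estimated at 900 nM, within a range from 250 nM to 3500 nM, which corresponds to an expected step of a 1.8-fold higher number from compound 1 to compound 3 (0.26 log units; within the scatter).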

Compound 3, half-maximal inhibitory concentration: 100 nM
Compound 3: middle estimate off by 9.0-fold (0.95 log units), on the high side; measured number below the stated range.
By their numbers in this assay, from the lowest: compound 3; then compound 1; then compound 2.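

Replacing hydroxy with (oxolan-3-yl)oxy gives a 4.9-fold lower number from compound 1 to compound 3 (0.69 log units; beyond the scatter) in this assay and so lowers the number. This shows that, in compound 3, the position on an oxygen on an aromatic ring accepts the oxolan-3-yl ring and that the hydrogen on that oxygen is not needed for a low number. No measurement at hand bears on the reason for this step. Still open, from the compounds shown here alone, is whether the oxolan-3-yl ring itself matters, or whether a methyl ether, a longer chain ending in an amine, or a carboxylic acid on this oxygen would give a similar number.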